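Methyl to sec-butyl at the assay's limit

A few compounds are considered here, and "the series" means these few. Any claim that something is new, unique, unknown or untested is made for them only; others in the source may bear on it.

In a functional assay on MDA-MB-231 cells (Homo sapiens) for inhibition, read by MTT assay, with a stated time of 72 h (on this read-out lower numbers stand for stronger inhibition and higher numbers for weaker inhibition), compound 1 `C[C@H](NC(=O)c1cc(Cl)ccc1OCCNC(=O)OC(C)(C)C)C(=O)Nc1ccc([N+](=O)[O-])cc1Cl` gives > 10000 nM as a limit, not a number. Compound 2 `C[C@H](NC(=O)c1cc(Cl)ccc1OCCN)C(=O)Nc1ccc([N+](=O)[O-])cc1Cl` gives > 10000 nM as a limit too. Compound 3 `CC(C)C[C@H](NC(=O)c1cc(Cl)ccc1OCCN)C(=O)Nc1ccc([N+](=O)[O-])cc1Cl` gives > 10000 nM as a limit also. Compound 1 therefore stands at the limit of > 10000 nM in this assay, at which 3 of the 3 values shown sit, and cannot be ranked further.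

Compound 4 `CC[C@@H](C)[C@H](NC(=O)c1cc(Cl)ccc1OCCNC(=O)OC(C)(C)C)C(=O)Nc1ccc([N+](=O)[O-])cc1Cl` differs from compound 1 by sec-butyl in place of methyl on a saturated chain carbon bound to an amide-type nitrogen and a carbonyl carbon with sec-butyl in place of methyl on a saturated chain carbon bound to an amide-type nitrogen and a carbonyl carbon. The measured steps a step that the two limits leave unreadable from compound 1 to compound 2 and a step that the two limits leave unreadable from compound 2 to compound 3 bear on this, the second more closely, yet neither has a readable size. The expected step is thus a step that the limit leaves unreadable from compound 1 to compound 4 with no clear direction in this assay and probably another limit. Compound 4 is estimated at 12000 nM with an expected range of 4000 nM to 30000 nM for a measured number.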

Compound 4, half-maximal inhibitory concentration: 4020 nM
Compound 4: the middle estimate sits 3.0-fold (0.47 log units) above what was measured, within the range that was stated.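

In this assay, the change of methyl to sec-butyl gives an at least 2.4-fold lower number from compound 1 to compound 4 (0.39 log units; beyond the scatter). Among the compounds shown here, the earlier steps cannot be read, so this is the first sign that the group on this saturated chain carbon can move the number. Compound 4 is also the only compound here with a measured number rather than a limit: the limit of > 10000 nM in this assay, at which 3 of the 4 values shown sit.

Still open, going by these compounds, is whether sec-butyl would lower the number in the same way with a free amine in place of tert-butoxycarbonyl. On these data alone, it is also open how a benzyl group or a longer straight chain at this carbon would compare.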